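Clearance notes: ethyl to isopropyl on the shared core

This account rests on a few compounds, and the source may have more. Where it says the series, first, only, none or still open, it means among the compounds named here.

Compound 3 `CCOc1cc([C@](O)(CCN(C)C)[C@@H](c2cc3cc(Br)ccc3nc2OC)c2ccnc(OC)c2OC)cc(OC)n1` gives 9.5 mL/min/kg in an ADME assay on the whole organism (Mus musculus, strain CD-1) for pharmacokinetics (on this read-out lower numbers stand for slow clearance and higher numbers for fast clearance), the lowest of the three numbers, though its distance to compound 2 `CCOc1cc([C@](O)(CCN(C)C)[C@H](c2cccc(C)c2)c2cc3cc(Br)ccc3nc2OC)cc(OC)n1` at 12 mL/min/kg and to compound 1 `CCOc1cc([C@](O)(CCN(C)C)[C@@H](c2cc3cc(Br)ccc3nc2OC)c2cccc(OC)c2F)cc(OC)n1` at 19 mL/min/kg is within the scatter. Compound 4 `COc1cc([C@](O)(CCN(C)C)[C@@H](c2cc3cc(Br)ccc3nc2OC)c2ccnc(OC)c2OC)cc(OC(C)C)n1` differs from compound 3 by methyl in place of hydrogen on a saturated chain carbon bound to an oxygen on an aromatic ring and a saturated chain carbon. Among the compounds with values here, none of the measured steps touches this part of the molecule: a 1.6-fold lower number from compound 1 to compound 2 (0.20 log units; within the scatter), a 2.0-fold lower number from compound 1 to compound 3 (0.30 log units; within the scatter) and a 1.3-fold lower number from compound 2 to compound 3 (0.10 log units; within the scatter) all vary the group on the saturated chain carbon bound to an aromatic carbon, and each stays within the scatter. Within the data shown here, with no step bearing on an ethoxy to isopropoxy change, no shift beyond the scatter is expected in this assay. Compound 4 is estimated at 10 mL/min/kg, with a range of 5 mL/min/kg to 20 mL/min/kg. The expected step is a 1.1-fold higher number from compound 3 to compound 4 (0.02 log units; within the scatter).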

Compound 4, clearance: 6.8 mL/min/kg
Beside the measured number, compound 4's estimate is 1.5-fold (0.17 log units) above it; low and high end bracket the measured number.
By their numbers in this assay, from the lowest: compounds 4, 3, 2 and 1 (each within the scatter of the next, the first and the last beyond it).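

Within the data shown here, this is the first step at this place: ethoxy to isopropoxy, a methyl in place of hydrogen on a saturated chain carbon bound to an oxygen on an aromatic ring and a saturated chain carbon, gives a 1.4-fold lower number from compound 3 to compound 4 (0.15 log units; within the scatter) in this assay and so stays within the scatter. On the compounds shown, this added methyl does not move clearance beyond the scatter. No measured evidence accounts for the step.

Still open, on these data alone, is whether a longer chain such as n-propoxy, or a tert-butoxy or cyclopropylmethoxy group, would behave the same way here. Also open, as far as these compounds go, is whether the methyl step carries over when 3-methylphenyl or 2-fluoro-3-methoxyphenyl replaces 2,3-dimethoxypyridin-4-yl.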